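Replacing Pyridin-2-yl with Furan-2-yl in a Weak Series

The source may hold more compounds than are shown below. What is called first, only, known or untested is meant among the compounds shown, and "the series" means these compounds.

Compound 1 `Oc1ccc(-c2cc(-c3cccc(Cl)c3)nc(-c3ccccn3)c2)cc1`: 27900 nM
Compound 2 `Oc1cccc(-c2cc(-c3ccc(Cl)cc3)nc(-c3ccccn3)c2)c1`: 13900 nM
Compound 3 `Oc1cccc(-c2cc(-c3cccc(Cl)c3)nc(-c3ccccn3)c2)c1`: "not determined" (no result reported)

Three close relatives were run in a functional assay on T47D cells (Homo sapiens) for cytotoxicity, read by CCK-8 assay and cell counting, with a stated time of 2 days; a higher number here means a weaker inhibitor, a lower number a stronger inhibitor. Compound 1 gives 27900 nM and compound 2 gives 13900 nM; both are weak, and the two values sit within the usual scatter of each other, so neither can be called the stronger. Compound 3 has no single number in this assay, so where it stands can only be guessed from its two neighbours, both of which are weak.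

Compound 4 `Oc1cccc(-c2cc(-c3cccc(Cl)c3)nc(-c3ccco3)c2)c1` is the next step. Compared with compound 3, the change is furan-2-yl in place of pyridin-2-yl on an aromatic carbon. With no measured step of this kind in the set, nothing here tells which way this assay will move or how far. The neighbouring values suggest a starting point in the weak range, and the swap of one small aromatic group for another is expected to shift the result by no more than the usual scatter. Compound 4 is therefore expected to give about 20000 nM, within a range from 5000 nM to 80000 nM.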

Compound 4, half-maximal inhibitory concentration: 3570 nM
For compound 4 the middle estimate is 5.6-fold (0.75 log units) above the measured one; measured number below the stated range.
By their numbers in this assay, from the lowest: compound 4; then compounds 2 and 1 (each within the scatter of the next).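

Compound 3 has no single number in this assay, so the swap of pyridin-2-yl for furan-2-yl leading to compound 4 cannot be read as a step. As far as these compounds go, whether furan-2-yl itself changes the value therefore stays open. No measurement shown explains the result of compound 4.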